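Phenyl for pentyl at the end of an aryloxy chain

The compounds below may be only part of what the source reports. "The series", "measured", "known", "first", "only" and "open" are said of these compounds alone.

Measured compounds:
compound 1 `CCCCCCCCOc1ccc2c(Cl)ccnc2c1` gives 4300 nM
compound 2 `CN(C)CCCNc1ccnc2cc(OCc3ccc(F)cc3)ccc12` gives 1280 nM

The read-out is a functional assay on SK-OV-3 cells (Homo sapiens) for cytotoxicity, read by MTT assay, with a stated time of 48 h; a higher number here means a weaker inhibitor, a lower number a stronger inhibitor. Of the two measured compounds, compound 1 stands at the highest number; compound 2 sits at a lower number, and that gap is beyond the scatter, so compound 2 is the stronger inhibitor of the pair. The two differ in several places, so nothing about any single change can be drawn from them.

Compound 3 `Clc1ccnc2cc(OCCCc3ccccc3)ccc12` is not yet measured. It differs from compound 1 in one place: phenyl in place of pentyl on a saturated chain carbon, three bonds along the chain from an oxygen on an aromatic ring. Among the measured compounds shown here, no measured pair in this set isolates such a change, so there is no directly comparable step. The expectation for this assay is therefore a step of no clear direction, most likely within the scatter, as a 1.2-fold lower number from compound 1 to compound 3 (0.09 log units; within the scatter). On that basis compound 3 is estimated at 3500 nM, with a range from 1400 nM to 9000 nM.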

Compound 3, half-maximal inhibitory concentration: 3610 nM
For compound 3 the middle estimate is 1.0-fold (0.01 log units) below the measured one, and the stated range covers the measured number.
By their numbers in this assay, from the lowest: compound 2; then compounds 3 and 1 (each within the scatter of the next).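

In this assay, phenyl in place of pentyl on a saturated chain carbon, three bonds along the chain from an oxygen on an aromatic ring, gives a 1.2-fold lower number from compound 1 to compound 3 (0.08 log units; within the scatter). Among the compounds shown here, this is the first comparison here that isolates one change, and it shows that at this position the aromatic ring and the open pentyl end cannot be told apart in these cells, at least in this single pair. Nothing available bears on why the two read alike.

From the compounds shown here alone, whether an amine, a carboxylic acid or a longer chain at this place would shift the number remains open. Compound 2 differs from compound 1 and compound 3 in several places, so it cannot show whether the same change would read alike on a different core.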